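The compounds below may be only part of what the source reports. "The series", "measured", "known", "first", "only" and "open" are said of these compounds alone.

Measured so far:
- compound 2, `CC(=O)OC[C@H]1O[C@@H](OCc2noc(-c3ccc([N+](=O)[O-])cc3)n2)[C@@H]2OC3(CCCC3)O[C@@H]21`: 29000 nM
- compound 1, `COc1cc(-c2nc(CO[C@@H]3O[C@H](CSc4ncn[nH]4)[C@H]4OC5(CCCC5)O[C@@H]34)no2)cc(OC)c1OC`: 28000 nM

In a functional assay on A549 cells (Homo sapiens) for antiproliferative activity, read by sulforhodamine B assay, with a stated time of 48 h (on this read-out higher numbers stand for weaker inhibition of growth and lower numbers for stronger inhibition of growth), compound 2 gives 29000 nM and compound 1 gives 28000 nM. On these two numbers compound 2 and compound 1 sit within the scatter of each other, so neither can be set apart from the other in this assay; both show only weak growth inhibition.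

Compound 3, `O=[N+]([O-])c1ccc(-c2nc(CO[C@@H]3O[C@H](CSc4ncn[nH]4)[C@H]4OC5(CCCC5)O[C@@H]34)no2)cc1`, is to be measured in this assay. It differs from compound 2 in one place: (1H-1,2,4-triazol-5-yl)sulfanyl in place of acetoxy on a saturated chain carbon bound to a saturated ring carbon. Compound 1 already carries the same ((1H-1,2,4-triazol-5-yl)sulfanyl)methyl arm on a different aryl part of the core, and its value in this assay lies with that of compound 2. No pair of measured compounds isolates this change, so the step cannot be read from the data; the weak and flat numbers of compound 1 and compound 2 give no reason to expect a move beyond the scatter in either direction.

The step from compound 2 to compound 3 is therefore expected to be small, a 1.1-fold lower number from compound 2 to compound 3 (0.05 log units; within the scatter), with a wide range allowed. For compound 3 in this assay the estimate is 26000 nM, between 8000 nM and 80000 nM.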

Compound 3, concentration for 50% growth inhibition: 10000 nM
Compound 3: the middle estimate sits 2.6-fold (0.41 log units) above what was measured; the measured number falls inside the stated range.
By their numbers in this assay, from the lowest: compound 3; then compounds 1 and 2 (each within the scatter of the next).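

In this assay, among the compounds shown here, (1H-1,2,4-triazol-5-yl)sulfanyl in place of acetoxy on a saturated chain carbon bound to a saturated ring carbon gives a 2.9-fold lower number from compound 2 to compound 3 (0.46 log units; beyond the scatter) as a modest step, the first reading of any change at this position. The aryl part also responds: 4-nitrophenyl in place of 3,4,5-trimethoxyphenyl on an aromatic carbon gives a 2.8-fold lower number from compound 1 to compound 3 (0.45 log units; beyond the scatter) as a second modest step, with the ((1H-1,2,4-triazol-5-yl)sulfanyl)methyl arm held constant. The two steps show that the flat pair of values for compound 1 and compound 2 did not mean that the series was insensitive to change, and compound 3 now has the lowest number of the three, although at 10000 nM compound 3 still sits in a range of weak growth inhibition.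

Going by these compounds, the arm change has been read only with 4-nitrophenyl in place, so its size with 3,4,5-trimethoxyphenyl stays open, as does the outcome with a primary amine or a carboxylic acid on the same chain carbon. No measurement at hand explains either step.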